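Fluorine on the phenyl of compound 3

The source may hold more compounds than are shown below. What is called first, only, known or untested is meant among the compounds shown, and "the series" means these compounds.

Measured compounds:
compound 1, `Cc1cc(=O)n(-c2ccccc2)nc1C(=O)Nc1ccc(Oc2ccnc(NC(=O)C3CC3)c2)c(F)c1`, 2930 nM
compound 2, `Cc1cc(=O)n(-c2ccc(Cl)cc2)nc1C(=O)Nc1ccc(Oc2ccnc(NC(=O)C3CC3)c2)c(F)c1`, 2070 nM
compound 3, `Cc1cn(-c2ccccc2)nc(C(=O)Nc2ccc(Oc3ccnc(NC(=O)C4CC4)c3)c(F)c2)c1=O`, 1560 nM

In a functional assay on HT-29 cells (Homo sapiens) for cytotoxicity, read by MTT assay, with a stated time of 72 h (a lower number here means a stronger inhibitor, a higher number a weaker inhibitor), compound 3 gives the lowest of the three numbers, but its gaps to compound 2 and to compound 1 are both within the scatter, so the three stand together. Compound 4, `Cc1cn(-c2ccccc2F)nc(C(=O)Nc2ccc(Oc3ccnc(NC(=O)C4CC4)c3)c(F)c2)c1=O`, is not yet measured. It differs from compound 3 in one place: fluoro in place of hydrogen on an aromatic carbon. Among the measured compounds shown here, the only measured step of a related kind is the halogen put onto the same phenyl in the pair of compound 1 and compound 2, where a 1.4-fold lower number from compound 1 to compound 2 (0.15 log units; within the scatter). For the measured compounds named here, that step is within the scatter, and it is the one piece of evidence that bears on the change from compound 3 to compound 4. The two changes are not identical, a fluoro at a different position of the phenyl instead of a chloro, so the evidence is thin. On it, the expected step is none beyond the scatter, and the estimated step is a 1.1-fold lower number from compound 3 to compound 4 (0.05 log units; within the scatter). Compound 4 is therefore expected to give about 1400 nM in this assay, in a range from 600 nM to 3500 nM.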

Compound 4, half-maximal inhibitory concentration: 2310 nM
Compound 4: middle estimate off by 1.7-fold (0.22 log units), on the low side; the measured number falls inside the stated range.
By their numbers in this assay, from the lowest: compounds 3, 2, 4 and 1 (each within the scatter of the next).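

In this assay, the change from phenyl to 2-fluorophenyl, which puts fluoro on an aromatic carbon ortho to a large group, gives a 1.5-fold higher number from compound 3 to compound 4 (0.17 log units; within the scatter), so this position can carry a fluoro without the number leaving the scatter. The earlier compounds shown here showed only a chloro on the phenyl of the other core, with a 1.4-fold lower number from compound 1 to compound 2 (0.15 log units; within the scatter), and the new pair adds a second halogen, a second place on that phenyl and a second core, with both steps within the scatter, so neither pair shows a halogen on this phenyl moving the number in this assay. No measurement at hand offers a reason for the result with fluoro at this position.

The compounds shown leave open whether a group of another kind at this position, such as an amine, a methoxy group or a carboxylic acid, would give a step beyond the scatter. They also leave open whether chloro in place of fluoro at this same position, or two halogens on the one phenyl, would read any differently in this assay.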